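Biphenyl amide series: cytotoxicity limits and a fluoro-methoxy analogue

This account rests on a few compounds, and the source may have more. Where it says the series, first, only, none or still open, it means among the compounds named here.

Measured so far in an ADME assay on HepG2 cells (Homo sapiens) for cytotoxicity, read by CellTiter-Glo and resazurin assay, with a stated time of 72 h; a lower number here means that less compound is needed, a higher number that more compound is needed for the effect:
compound 1 `CCOC(=O)CCCCCOc1cccc(CN(C(=O)c2ccc(-c3cccc(-c4ccccc4)c3)cc2)C(C)C)c1` gives > 26000 nM, a limit of the assay.
compound 2 `CCOC(=O)CCCCCOc1cccc(CN(C(=O)c2ccc(-c3ccc(C(C)=O)s3)cc2)C(C)C)c1` gives > 26000 nM, a limit of the assay.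
compound 3 `CCOC(=O)CCCCCOc1cccc(CN(C(=O)c2ccc(-c3cccc(OC(F)(F)F)c3)cc2)C(C)C)c1` gives > 26000 nM, a limit of the assay.

Compound 3 stands only at a limit in this assay, and the two other values shown are limits as well; all three sit at the same ceiling (the limit of > 26000 nM in this assay, at which 3 of the 3 values shown sit), so no order among them can be read.

Compound 4 `CCOC(=O)CCCCCOc1cccc(CN(C(=O)c2ccc(-c3cc(OC)ccc3F)cc2)C(C)C)c1` is not yet measured. The change from compound 3 is 2-fluoro-5-methoxyphenyl in place of 3-(trifluoromethoxy)phenyl on an aromatic carbon.

The measured steps bear on it only loosely. The step that the two limits leave unreadable from compound 1 to compound 2, the step that the two limits leave unreadable from compound 1 to compound 3 and the step that the two limits leave unreadable from compound 2 to compound 3 are each unreadable, since both ends sit at the limit. Three quite different groups on the same aromatic carbon of the shared core have therefore left the read-out at the limit, and the change to compound 4 is of similar kind and size. No step beyond the scatter is expected in this assay for compound 4.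

Compound 4 is expected to give 30000 nM, between 15000 nM and 60000 nM, most likely again reported as a limit, so that the step that the limit leaves unreadable from compound 3 to compound 4 is expected to be essentially none.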

Compound 4, half-maximal effective concentration: > 26000 nM
Compound 4: no number, only a limit (the forecaster's own chance of this, stated with the estimate: 85%); the middle value lies beyond the limit too.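

In this assay compound 4 gives > 26000 nM, a limit of the assay. No new step can be read from compound 1, compound 2 or compound 3 to compound 4, because all values sit at one ceiling: the limit of > 26000 nM in this assay, at which 4 of the 4 values shown sit.

The compounds shown leave open whether any group at this place on the shared core gives a measurable value in this assay.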